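Fluoro in Place of Bromo: What to Expect in Cells

The source may hold more compounds than are shown below. What is called first, only, known or untested is meant among the compounds shown, and "the series" means these compounds.

Measured compounds:
Compound 1 `O=C(/C=C/c1ccc(F)c(Br)c1)c1ccc(B(O)O)cc1` — 9500 nM
Compound 2 `O=C(/C=C/c1ccccc1)c1ccc[nH]1` — 15000 nM

Of the compounds shown here, two have been tested in a functional assay on MDA-MB-231 cells (Homo sapiens) for inhibition; on this read-out lower numbers stand for stronger inhibition and higher numbers for weaker inhibition. Compound 1 gives 9500 nM, and compound 2 gives 15000 nM. Compound 1 carries the lowest of the two numbers, but the gap to compound 2 lies within the usual scatter of this assay, so the two cannot be ranked against each other. Among the measured compounds shown here, the two compounds also differ in several places at once, so no single structural step connects them and nothing can be learned about the effect of any one change.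

Compound 3 `O=C(/C=C/c1ccc(F)c(F)c1)c1ccc(B(O)O)cc1` is not yet measured. It differs from compound 1 in one place: fluoro in place of bromo on an aromatic carbon. For the measured compounds named here, since no measured pair shows what such a change does here, the expectation rests on the value of compound 1 alone. A step of this kind is expected to stay small, with at most a slight weakening, and quite possibly none beyond the scatter: the expected step is a 1.3-fold higher number from compound 1 to compound 3 (0.10 log units; within the scatter). Compound 3 is therefore estimated at 12000 nM, within a range from 4000 nM to 36000 nM.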

Compound 3, half-maximal inhibitory concentration: 8800 nM
Estimate against measurement, compound 3: 1.4-fold (0.13 log units) above, and the stated range covers the measured number.
By their numbers in this assay, from the lowest: compounds 3, 1 and 2 (each within the scatter of the next).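

In this assay, fluoro in place of bromo on this aromatic carbon gives a 1.1-fold lower number from compound 1 to compound 3 (0.03 log units; within the scatter) and so leaves the two compounds indistinguishable. Among the compounds shown here, this is the first comparison here that changes a single place, which the pair of compound 1 and compound 2 could not offer: on this carbon, ortho to a fluoro group and meta to a large group, the read-out does not separate bromo from fluoro, although the two groups differ in the atom they carry. Nothing measured on these compounds bears on why the two read the same.

Bromo and fluoro are the only groups shown on this carbon, so one matching pair says little about the position as a whole, and it remains open whether the read-out would also hold with plain hydrogen there, or shift with an amine, a methoxy group or a carboxylic acid. As far as these compounds go, it is equally open how much the rest of the shared core matters, for instance whether the boronic acid could give way to a carboxylic acid on the same ring without moving the number beyond the scatter.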